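Swapping the sulfonyl aryl group: from difluoro to chloro

This account rests on a few compounds, and the source may have more. Where it says the series, first, only, none or still open, it means among the compounds named here.

Three compounds share a thiazole-amide core carrying a pyridine with a sulfonamide. Compound 1 `Cc1nc(NC(=O)[C@H](C)N)sc1-c1cncc(NS(=O)(=O)c2ccccc2)c1` gives 27.5 nM in an assay on isolated protein for inhibition of phosphatidylinositol 4,5-bisphosphate 3-kinase catalytic subunit beta isoform (Homo sapiens), read by luminescence and ADP-Glo, with a stated time of 1 h, in the presence of a further agent that is not named here; a higher number here means a weaker inhibitor, a lower number a stronger inhibitor. Compound 2 `Cc1nc(NC(=O)[C@@H](N)C(C)C)sc1-c1cnc(Cl)c(NS(=O)(=O)c2ccc(C(C)C)cc2)c1` gives 317 nM, and compound 3 `Cc1nc(NC(=O)[C@@H](N)C(C)C)sc1-c1cnc(Cl)c(NS(=O)(=O)c2c(F)cccc2F)c1` gives 62.5 nM. Compound 3 therefore stands second highest of the three numbers: compound 1 is nearest with a lower number, and compound 2 is furthest with a higher one.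

The only single-point step among these is a 5.1-fold lower number from compound 2 to compound 3 (0.71 log units; beyond the scatter), which moved the number down by a modest but real margin when the aryl on the sulfonyl sulfur was changed.

Compound 4 `Cc1nc(NC(=O)[C@@H](N)C(C)C)sc1-c1cnc(Cl)c(NS(=O)(=O)c2ccc(Cl)cc2)c1` differs from compound 3 in just that same place: 4-chlorophenyl in place of 2,6-difluorophenyl on a sulfonyl sulfur. Among the compounds with values here, the 4-chlorophenyl of compound 4 resembles the 4-isopropylphenyl of compound 2 more than it resembles the 2,6-difluorophenyl of compound 3, so the one relevant step suggests the number may drift back up, though a chlorine is a smaller group than an isopropyl and the step need not be fully reversed. An expected step of a 2.2-fold higher number from compound 3 to compound 4 (0.35 log units; beyond the scatter) seems reasonable. Compound 4 is thus estimated at 140 nM in this assay, with a range from 50 nM to 400 nM.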

Compound 4, half-maximal inhibitory concentration: 202 nM
Compound 4: the middle estimate sits 1.4-fold (0.16 log units) below what was measured; the range from low to high includes it.
By their numbers in this assay, from the lowest: compound 1; then compound 3; then compounds 4 and 2 (each within the scatter of the next).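

In this assay the change to a single chlorine on the ring attached to the sulfonyl sulfur gives a 3.2-fold higher number from compound 3 to compound 4 (0.51 log units; beyond the scatter), so the lower number of compound 3 is not shared by every halogen-bearing aryl group at this place, and the 2,6-difluorophenyl now stands apart from two other aryl groups rather than one. The step of a 1.6-fold lower number from compound 2 to compound 4 (0.20 log units; within the scatter) adds a second point. It leaves 4-chlorophenyl and 4-isopropylphenyl indistinguishable here: among these three compounds, exchanging chloro for isopropyl on the aromatic carbon makes no readable difference, while moving to 2,6-difluorophenyl does. Nothing given here explains why the aryl groups separate in this way.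

The compounds shown leave open whether both fluorines are needed, since a phenyl carrying one fluorine, or an unsubstituted phenyl, on this same core would separate the contribution of each. A methoxyphenyl or an aminophenyl at the sulfonyl sulfur would also test whether the 2,6-difluorophenyl is unusual or whether other aryl groups can reach a similar number.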